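Adding a methoxy to the benzoyl group of compound 3

The compounds below may be only part of what the source reports. "The series", "measured", "known", "first", "only" and "open" are said of these compounds alone.

In a functional assay on HepG2 cells (Homo sapiens) for inhibition, read by MTT assay, with a stated time of 24 h (on this read-out higher numbers stand for weaker inhibition of growth and lower numbers for stronger inhibition of growth), compound 3 (`Cn1cc(-c2nc3ccccc3n2C(=O)c2ccccc2)c2cc(Br)ccc21`) gives 48100 nM. This lies within the scatter of compound 1 (`COc1ccccc1C(=O)n1c(-c2cn(C)c3ccccc23)nc2ccccc21`) at 31800 nM, while compound 2 (`COc1ccc2c(c1)c(-c1nc3ccccc3n1C(=O)c1ccccc1OC)cn2C`) at 23600 nM lies lower, beyond the scatter. Compound 4 (`COc1ccccc1C(=O)n1c(-c2cn(C)c3ccc(Br)cc23)nc2ccccc21`) differs from compound 3 by methoxy in place of hydrogen on an aromatic carbon, which turns benzoyl into (2-methoxyphenyl)carbonyl. Within the data shown here, the only measured step of this kind is a 1.3-fold lower number from compound 1 to compound 2 (0.13 log units; within the scatter), and it does not fall at the same place, so it is a loose guide. No step beyond the scatter is therefore expected in this assay. The expected step is a 1.3-fold lower number from compound 3 to compound 4 (0.13 log units; within the scatter). Compound 4 is estimated at 36000 nM, with an expected range of 19000 nM to 65000 nM.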

Compound 4, concentration for 50% growth inhibition: 34600 nM
Estimate against measurement, compound 4: 1.0-fold (0.02 log units) above, and the stated range covers the measured number.
By their numbers in this assay, from the lowest: compounds 2, 1, 4 and 3 (each within the scatter of the next, the first and the last beyond it).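

In this assay, methoxy ortho to a large group on the benzoyl ring gives a 1.4-fold lower number from compound 3 to compound 4 (0.14 log units; within the scatter), so this position tolerates the change without a step beyond the scatter. Bromo in place of methoxy gives a 1.5-fold higher number from compound 2 to compound 4 (0.17 log units; within the scatter), and bromo in place of hydrogen gives a 1.1-fold higher number from compound 1 to compound 4 (0.04 log units; within the scatter), so neither replacement on the core separates compound 4 from its neighbours. The methoxy step also reads alike on both cores: the same change on two cores in this assay, a 1.3-fold lower number (0.13 log units; within the scatter) from compound 1 to compound 2 and a 1.4-fold lower number (0.14 log units; within the scatter) from compound 3 to compound 4, 1.0-fold (0.01 log units) apart, within the scatter of two such steps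

The compounds shown leave open whether an amine or a carboxylic acid at this ortho position would give a step beyond the scatter. They also leave open whether methoxy elsewhere on that ring would read the same.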